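Anilide series on the shared core: fluoro at the aromatic ring

The source may hold more compounds than are shown below. What is called first, only, known or untested is meant among the compounds shown, and "the series" means these compounds.

Compounds sharing the core of compound 1 `O=C(O)CCc1cccc2c1B(O)OC2` were tested in an ADME assay on WI-38 cells (Homo sapiens) for cytotoxicity, read by MTT assay, with a stated time of 72 h; on this read-out higher numbers stand for weaker inhibition and lower numbers for stronger inhibition. Compound 1 gives only a limit of the assay, > 100000 nM. Compound 2 `CC(C)(C)NC(=O)CCc1cccc2c1B(O)OC2` likewise returns only a limit, > 100000 nM. Going by the values given here, compound 3 `O=C(CCc1cccc2c1B(O)OC2)Nc1ccccc1` is the one member with a number, 30000 nM, and so stands as the reference point of the set. The other two values sit at a limit of the assay (the limit of > 100000 nM in this assay, at which 2 of the 3 values shown sit). The measured steps of an at least 3.3-fold lower number from compound 1 to compound 3 (0.52 log units; beyond the scatter) and an at least 3.3-fold lower number from compound 2 to compound 3 (0.52 log units; beyond the scatter) both concern the amide substituent and not the aromatic ring of the anilide.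

Compound 4 `O=C(CCc1cccc2c1B(O)OC2)Nc1ccc(F)cc1` differs from compound 3 by fluoro in place of hydrogen on an aromatic carbon. Among the compounds with values here, no measured step touches a change on this aromatic ring, so the steps above give no size to carry over; the expected step in this assay is therefore none beyond the scatter, a 1.2-fold lower number from compound 3 to compound 4 (0.08 log units; within the scatter). Compound 4 is accordingly estimated at 25000 nM, with a range from 10000 nM to 80000 nM.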

Compound 4, half-maximal inhibitory concentration: 12000 nM
For compound 4 the middle estimate is 2.1-fold (0.32 log units) above the measured one; measured number inside the range.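

Until now every measured step concerned the group on the amide nitrogen; the aromatic ring of the anilide now also proves responsive. Fluoro on the aromatic carbon para to a large group gives a 2.5-fold lower number from compound 3 to compound 4 (0.40 log units; beyond the scatter) in this assay and so moves the series towards stronger inhibition of these cells. Against the tert-butyl amide, 4-fluorophenyl gives an at least 8.3-fold lower number from compound 2 to compound 4 (0.92 log units; beyond the scatter) and this remains a bound rather than a size: the limit of > 100000 nM in this assay, at which 2 of the 4 values shown sit.

A single fluoro at a single place leaves open whether chloro, methoxy or fluoro elsewhere on this ring would move the number in the same way. Also open, as far as these compounds go, is how an amine or a carboxylic acid on the ring, or a longer chain leading to the amide, would read.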